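Adding ethoxycarbonyl to compound 2

The compounds below may be only part of what the source reports. "The series", "measured", "known", "first", "only" and "open" are said of these compounds alone.

compound 1 `O=C(Nc1cccc(F)c1)N1c2ccnn2CC1c1ccccc1` gives > 1000 nM
compound 2 `O=C(Nc1ccc(F)cc1)N1c2ccnn2CC1c1ccccc1` gives > 1000 nM
compound 3 `O=C(Nc1cccc2ccccc12)N1c2ccnn2CC1c1ccccc1` gives > 1000 nM

In a functional assay on cells (Neutrophil, Homo sapiens) for inhibition, with a stated time of 10 min (a higher number here means a weaker inhibitor, a lower number a stronger inhibitor), compound 2 gives > 1000 nM as a limit and not a number. The whole picture so far is the limit of > 1000 nM in this assay, at which 3 of the 3 values shown sit, and no exact potency is known for any of these compounds. Compound 4 `CCOC(=O)c1cnn2c1N(C(=O)Nc1ccc(F)cc1)C(c1ccccc1)C2` differs from compound 2 by ethoxycarbonyl in place of hydrogen on an aromatic carbon and has not yet been measured. Within the data shown here, the only measured step is a step that the two limits leave unreadable from compound 1 to compound 2 and it concerns a different place, so it offers no size to carry over. No direction can be read from the data, and another limit would be unsurprising. The expected change is a number no higher from compound 2 to compound 4 (the limit leaves the size open) with wide uncertainty. Compound 4 is estimated at 1000 nM in this assay, with an expected range from 50 nM to 5000 nM as its ends.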

Compound 4, half-maximal inhibitory concentration: > 1000 nM
Compound 4: only a limit was reported (the forecaster's own chance of this, stated with the estimate: 55%); the middle value lies on the limit itself.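

Compound 2 and compound 4 are both reported only as limits, so the step between them cannot be read. The exact potency of every compound shown stays open, since all share one reading: the limit of > 1000 nM in this assay, at which 4 of the 4 values shown sit.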